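The source may hold more compounds than are shown below. What is called first, only, known or untested is meant among the compounds shown, and "the series" means these compounds.

Working notes on the series built on the shared core of compound 1 `CC#CC(CC(=O)O)c1ccc(OCc2ccc(C(=O)N3CCN(C)CC3)s2)cc1`, varied on an amine nitrogen in a ring. In a functional assay on HEK293 cells for agonist activity at Free fatty acid receptor 1 (Homo sapiens), read by fluorescence and calcium flux (on this read-out lower numbers stand for an effect already at smaller amounts and higher numbers for an effect only at larger amounts of compound), compound 1 reports only a limit, > 5000 nM, that is the limit of > 5000 nM in this assay, at which 1 of the 3 values shown sits. Compound 2 `CC#CC(CC(=O)O)c1ccc(OCc2ccc(C(=O)N3CCN(C4CCCCC4)CC3)s2)cc1` gives 820 nM and compound 3 `CC#CC(CC(=O)O)c1ccc(OCc2ccc(C(=O)N3CCN(c4cccnc4)CC3)s2)cc1` gives 1140 nM; compound 2 thus holds the lowest of the two numbers, with compound 3 within the scatter of it. The measured steps: an at least 6.0-fold lower number from compound 1 to compound 2 (0.78 log units; beyond the scatter); an at least 4.3-fold lower number from compound 1 to compound 3 (0.64 log units; beyond the scatter); a 1.4-fold higher number from compound 2 to compound 3 (0.14 log units; within the scatter). Compound 4 `CC#CC(CC(=O)O)c1ccc(OCc2ccc(C(=O)N3CCN(c4cccc(F)c4)CC3)s2)cc1` differs from compound 2 by 3-fluorophenyl in place of cyclohexyl on an amine nitrogen in a ring. The step from compound 2 to compound 3, also an aromatic ring in place of cyclohexyl, lay within the scatter, so no step beyond the scatter is expected here. The expected step is a 1.0-fold lower number from compound 2 to compound 4 (0.01 log units; within the scatter). For compound 4 the estimate in this assay is 800 nM, within 300 nM to 2500 nM.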

Compound 4, half-maximal effective concentration: 97 nM
The estimate for compound 4 lay 8.2-fold (0.92 log units) above the measured number, and the stated range ends above it.
By their numbers in this assay, from the lowest: compound 4; then compounds 2 and 3 (each within the scatter of the next). At a limit, above all of these: compound 1.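

In this assay, an aromatic ring on the amine nitrogen in a ring does not by itself set the number: pyridin-3-yl and cyclohexyl lay within the scatter of each other, whereas 3-fluorophenyl gives an 8.5-fold lower number from compound 2 to compound 4 (0.93 log units; beyond the scatter) and a 12-fold lower number from compound 3 to compound 4 (1.07 log units; beyond the scatter). Against methyl, the change gives an at least 51-fold lower number from compound 1 to compound 4 (1.71 log units; beyond the scatter). Compound 1 stands only at a limit, so this step is a bound: the limit of > 5000 nM in this assay, at which 1 of the 4 values shown sits.

The compounds shown leave open whether the fluorine or the phenyl ring carries the step. From the compounds shown here alone, how plain phenyl or 3-chlorophenyl would read on the same nitrogen also remains open.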